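Carboxycyclopropyl in place of carboxyethyl on the amide

The source may report more compounds than this note shows. Statements on the series, on what has been measured and on what is new or still open speak of the compounds shown alone.

Three amides on the shared core have been measured in a functional assay on MCF7 cells (Homo sapiens) for antiproliferative activity, read by MTT assay, with a stated time of 24 h; a lower number here means a stronger inhibitor, a higher number a weaker inhibitor. Compound 1 `CCn1c(C(=O)NCCO)ccc1C(CC)(CC)c1ccc(OCS(=O)(=O)c2ccccc2)c(C)c1` gives 15500 nM, compound 2 `CCn1c(C(=O)N[C@H](CO)CCCO)ccc1C(CC)(CC)c1ccc(OCS(=O)(=O)c2ccccc2)c(C)c1` gives 31400 nM and compound 3 `CCn1c(C(=O)N[C@@H](C)C(=O)O)ccc1C(CC)(CC)c1ccc(OCS(=O)(=O)c2ccccc2)c(C)c1` gives 35500 nM. Compound 3 cannot be separated from its nearest value, a 1.1-fold higher number from compound 2 to compound 3 (0.05 log units; within the scatter), but it is separated from its furthest, a 2.3-fold higher number from compound 1 to compound 3 (0.36 log units; beyond the scatter).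

Compound 4 `CCn1c(C(=O)NC2(C(=O)O)CC2)ccc1C(CC)(CC)c1ccc(OCS(=O)(=O)c2ccccc2)c(C)c1` carries 1-carboxycyclopropyl in place of 1-carboxyethyl on an amide-type nitrogen. For the measured compounds named here, no measured step introduces this ring, so the evidence is indirect. The closest guide is the other exchange between groups on that nitrogen that leaves a carboxyl-bearing compound in the comparison, a 1.1-fold higher number from compound 2 to compound 3 (0.05 log units; within the scatter) together with the modest 2.3-fold higher number from compound 1 to compound 3 (0.36 log units; beyond the scatter). The remaining measured step is also modest, a 2.0-fold higher number from compound 1 to compound 2 (0.31 log units; beyond the scatter). All three changes in the amide group therefore stay small, and a large move in this assay is not expected.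

The expected change, none beyond the scatter, is a 1.1-fold lower number from compound 3 to compound 4 (0.05 log units; within the scatter). Compound 4 is estimated at 32000 nM, with an expected range of 15000 nM to 65000 nM.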

Compound 4, half-maximal inhibitory concentration: 41200 nM
Compound 4: middle estimate off by 1.3-fold (0.11 log units), on the low side, within the range that was stated.
By their numbers in this assay, from the lowest: compound 1; then compounds 2, 3 and 4 (each within the scatter of the next).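

In this assay, 1-carboxycyclopropyl in place of 1-carboxyethyl on the amide-type nitrogen brings in the first three-membered ring of the series and removes the defined stereocentre of that group, yet a 1.2-fold higher number from compound 3 to compound 4 (0.06 log units; within the scatter) does not separate the two compounds, and neither does a 1.3-fold higher number from compound 2 to compound 4 (0.12 log units; within the scatter). The step from compound 4 that does lie beyond the scatter is a 2.7-fold higher number from compound 1 to compound 4 (0.42 log units; beyond the scatter), so the 2-hydroxyethyl group of compound 1 remains apart from the group on compound 4, as it does from those on compound 2 and compound 3. No evidence on the cause of these results is available here.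

Open, on these data alone, is whether a 1-carboxycyclobutyl group, or a methyl ester or primary amine in place of the carboxyl group, would separate from compound 4. Also open, as far as these compounds go, is whether the mirror-image form of the 1-carboxyethyl group would separate from compound 3.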